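The source may report more compounds than this note shows. Statements on the series, on what has been measured and on what is new or still open speak of the compounds shown alone.

Measured compounds:
compound 1, `COc1cc(CNC(=O)/C=C/c2ccc(OCc3nc(C)c(C)nc3C)c(OC)c2)ccc1O`; in a functional assay on SH-SY5Y cells (Homo sapiens) for cytotoxicity, read by MTT assay, with stated times of 24 h and 4 h (on this read-out lower numbers stand for an effect already at smaller amounts and higher numbers for an effect only at larger amounts of compound), compound 1 gives 10200 nM.
compound 2, `COc1cc(/C=C/C(=O)NCc2ccc(OCc3nc(C)c(C)nc3C)c(OC)c2)ccc1OCc1nc(C)c(C)nc1C`; in this assay compound 2 gives 11100 nM.
compound 3, `COc1ccc(OC)c(/C=C/C(=O)NCc2ccc(O)c(OC)c2)c1`; in this assay compound 3 gives 9500 nM.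

Compound 1 and compound 2 differ in one place only: (3,5,6-trimethylpyrazin-2-yl)methyl in place of hydrogen on an oxygen on an aromatic ring. In this assay that change gave a 1.1-fold higher number from compound 1 to compound 2 (0.04 log units; within the scatter), so the two values sit within the usual scatter of each other and no order can be read from them.

Compound 4, `COc1ccc(OC)c(/C=C/C(=O)NCc2ccc(OCc3nc(C)c(C)nc3C)c(OC)c2)c1`, is not yet measured. It stands to compound 3 exactly as compound 2 stands to compound 1, carrying the same change, ((3,5,6-trimethylpyrazin-2-yl)methyl in place of hydrogen on an oxygen on an aromatic ring), at a place described in the same words for both pairs. The cores of compound 1 and compound 3 are not the same, but the difference between the two cores is not broken down here. The values of compound 1 and compound 3 lie close together.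

For compound 4 the step is expected to be small, because the same change in the measured pair gave a 1.1-fold higher number from compound 1 to compound 2 (0.04 log units; within the scatter), and the expected step is a 1.1-fold higher number from compound 3 to compound 4 (0.02 log units; within the scatter). Compound 4 is accordingly estimated at 10000 nM in this assay, with a likely range from 5000 nM to 20000 nM.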

Compound 4, half-maximal effective concentration: 11000 nM
The estimate for compound 4 lay 1.1-fold (0.04 log units) below the measured number; the measured number falls inside the stated range.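

In this assay, the change from hydroxy to (3,5,6-trimethylpyrazin-2-yl)methoxy gives a 1.2-fold higher number from compound 3 to compound 4 (0.06 log units; within the scatter), so on this core, too, no order can be read from the two values. Carried from one core to the other, the change reads alike, and the two steps cannot be told apart: the same change on two cores in this assay, a 1.1-fold higher number (0.04 log units; within the scatter) from compound 1 to compound 2 and a 1.2-fold higher number (0.06 log units; within the scatter) from compound 3 to compound 4, 1.1-fold (0.03 log units) apart, within the scatter of two such steps

Among these compounds, this shows only that, on these two cores in this assay, the change leaves the number within the scatter; with no step of real size on either core, the pairs cannot show whether a larger effect would carry over, and two pairs set no rule for other cores.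

Going by these compounds, it remains open whether a different group on the same oxygen, such as a longer alkyl chain, a chain ending in an amine or one ending in a carboxylic acid, would take the number beyond the scatter. On these data alone, it also remains open whether (3,5,6-trimethylpyrazin-2-yl)methyl would read the same on a core without the amide.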